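This account rests on a few compounds, and the source may have more. Where it says the series, first, only, none or still open, it means among the compounds named here.

Measured so far in a functional assay on DWD cells (Homo sapiens) for inhibition, read by sulforhodamine B assay; on this read-out higher numbers stand for weaker inhibition of growth and lower numbers for stronger inhibition of growth

- compound 1 `COc1cc(-c2ccc(-c3ccc(-c4nc5cc(C)ccc5[nH]4)cc3)cc2)cc(OC)c1OC` gives 170 nM
- compound 2 `COc1ccc(-c2ccc(-c3ccc(-c4nc5ccccc5[nH]4)cc3)cc2)cc1` gives 100000 nM
- compound 3 `CN(C)c1ccc(-c2ccc(-c3ccc(-c4nc5ccccc5[nH]4)cc3)cc2)cc1` gives 100000 nM

Compound 1 has the lowest number of the three, and its gap to compound 2 and to compound 3 lies far beyond the scatter. Compound 4 `COc1cc(-c2ccc(-c3ccc(-c4nc5ccccc5[nH]4)cc3)cc2)cc(OC)c1OC` is compound 1 with hydrogen in place of methyl on an aromatic carbon, a change that counts as hydrogen in place of methyl on an aromatic carbon and touches nothing else. Going by the values given here, the only one-place step measured so far is no change at the digits printed from compound 2 to compound 3 (within the scatter) and it concerns a different group, so it gives no direct measure for this methyl. Compound 2 and compound 3 also lack the methyl, but they differ from compound 1 elsewhere too, so their high numbers cannot be assigned to it. Only a single methyl leaves, so a modest expected step toward weaker inhibition of growth seems most reasonable, estimated as a 2.4-fold higher number from compound 1 to compound 4 (0.37 log units; beyond the scatter) in size. In this assay the estimated value for compound 4 is 400 nM within an expected range of 80 nM to 4000 nM.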

Compound 4, concentration for 50% growth inhibition: 8010 nM
Compound 4: the middle estimate sits 20-fold (1.30 log units) below what was measured; the measured number lies above the stated range.
By their numbers in this assay, from the lowest: compound 1; then compound 4; then compounds 2 and 3 (each within the scatter of the next).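

In this assay the single methyl on the six-membered aromatic ring of carbon only turns out to matter far more than its size might suggest, since replacing it with hydrogen gives a 47-fold higher number from compound 1 to compound 4 (1.67 log units; beyond the scatter) with nothing else in the structure altered. Going by these compounds alone, this is the first direct measure at this position, and it shows that one carbon atom here can account for a large part of the potency of compound 1. The data at hand offer no explanation for so large a step from so small a change.

Whether methyl is the best group at this position stays open, as an ethyl, a chlorine or an amine in its place is not among the compounds shown. Also open, on these data alone, is whether adding the methyl to compound 2 or compound 3 would lower their numbers in the same way.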